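The compounds below may be only part of what the source reports. "The series", "measured", "known", "first", "only" and "open" are said of these compounds alone.

Measured compounds:
compound 1 `O=C(NCc1cccc(Cl)c1)c1ccc2cn(CCn3cccn3)nc2c1`, 173 nM
compound 2 `O=C(NCc1cccc(Cl)c1)c1cc(Cl)c2cn(CCn3cccn3)nc2c1`, 225 nM
compound 3 `COc1cc(C(=O)N2CC(C)(CCO)OC[C@H]2C)cc2nc(N[C@H](C)c3cccc(Cl)c3)oc12`, 0.5 nM

In an assay on isolated protein for inhibition of thyroid hormone receptor beta (Homo sapiens), read by fluorescence, with a stated time of 30 min (a lower number here means a stronger inhibitor, a higher number a weaker inhibitor), compound 3 gives the lowest of the three numbers; compound 1 sits a good way higher and compound 2 higher still, both gaps beyond the scatter. Compound 4 `COc1cc(C(=O)N2C[C@@H](C)OC[C@H]2CCO)cc2nc(N[C@H](C)c3cccc(Cl)c3)oc12` differs from compound 3 by 5-(2-hydroxyethyl)-2-methylmorpholin-4-yl in place of 2-(2-hydroxyethyl)-2,5-dimethylmorpholin-4-yl on a carbonyl carbon. Going by the values given here, the only measured step, a 1.3-fold higher number from compound 1 to compound 2 (0.11 log units; within the scatter), is a different change on a different core and does not bear on this rearrangement of substituents within the ring on the carbonyl carbon. With nothing comparable to go by, compound 4 is expected to stay close to compound 3, perhaps with a modest loss, a 2.0-fold higher number from compound 3 to compound 4 (0.30 log units; within the scatter). Compound 4 is therefore estimated at 1 nM, in the range 0.3 nM to 4 nM.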

Compound 4, half-maximal inhibitory concentration: 6 nM
Estimate against measurement, compound 4: 6.0-fold (0.78 log units) below; the measured number lies above the stated range.
By their numbers in this assay, from the lowest: compound 3; then compound 4; then compounds 1 and 2 (each within the scatter of the next).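

In this assay, going by these compounds alone, 5-(2-hydroxyethyl)-2-methylmorpholin-4-yl in place of 2-(2-hydroxyethyl)-2,5-dimethylmorpholin-4-yl on a carbonyl carbon gives a 12-fold higher number from compound 3 to compound 4 (1.08 log units; beyond the scatter) and shows that the number responds strongly to the substitution of this ring, which the earlier compounds did not vary. No evidence is available to account for this step. The compounds shown do not separate the effect of the changed hydroxyethyl placement from that of the lost methyl. Going by these compounds, whether an amine or a longer chain in place of 2-hydroxyethyl would keep the number low remains open.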